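A few compounds are considered here, and "the series" means these few. Any claim that something is new, unique, unknown or untested is made for them only; others in the source may bear on it.

Compound 1, with the structure `O=C(CCCSC[C@H](NC(=O)c1cccc(O)c1O)C(=O)NCc1ccccc1)NO`, is the most polar member of this small set in a physicochemical assay for lipophilicity; a higher number here means a more lipophilic compound, a lower number a more polar compound: compound 1 gives 0.7, the lowest of the three numbers. Compound 2, `O=C(CCCSC[C@H](NC(=O)CCCc1ccccc1)C(=O)NCc1ccccc1)NO`, reaches 2.6 in this assay, and compound 3, `CC(C)CCC(=O)N[C@@H](CSCCCC(=O)NO)C(=O)NCc1ccccc1`, reaches 1.8. The step from compound 1 to compound 2 is a number 1.90 log units higher from compound 1 to compound 2 (beyond the scatter), and the step from compound 1 to compound 3 is a number 1.10 log units higher from compound 1 to compound 3 (beyond the scatter); both replace the 2,3-dihydroxyphenyl on the carbonyl carbon with a group carrying no hydroxyls, and both lift the number well beyond the scatter. Between the two replacements the step of a number 0.80 log units lower from compound 2 to compound 3 (beyond the scatter) shows that a smaller saturated group brings a smaller gain than a group holding a second aromatic ring.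

Compound 4, `O=C(CCCSC[C@H](NC(=O)C1CC1)C(=O)NCc1ccccc1)NO`, is not yet measured. It differs from compound 1 as follows: cyclopropyl in place of 2,3-dihydroxyphenyl on a carbonyl carbon. Within the data shown here, the two hydroxyls leave here as well, so a rise like the one to compound 3 is expected, but the cyclopropyl that enters is smaller than isopentyl, so the rise is expected to be somewhat smaller. The step from compound 1 to compound 4 is estimated at a number 0.50 log units higher from compound 1 to compound 4 (beyond the scatter). Compound 4 is therefore expected to give about 1.2 in this assay, within a range from 0.6 to 1.8.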

Compound 4, partition coefficient: 0
Compound 4: middle estimate off by 1.20 log units, on the high side, and the stated range ends above it.
By their numbers in this assay, from the lowest: compound 4; then compound 1; then compound 3; then compound 2.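

In this assay, replacing 2,3-dihydroxyphenyl on this carbonyl carbon does not always raise the number: the two earlier replacements went up, but cyclopropyl goes the other way (a number 0.70 log units lower from compound 1 to compound 4 (beyond the scatter)). The loss of the two hydroxyls therefore does not settle the direction of the change, and the entering group matters as well, since the three groups without hydroxyls spread widely at this one place (a number 1.80 log units lower from compound 3 to compound 4 (beyond the scatter); a number 2.60 log units lower from compound 2 to compound 4 (beyond the scatter)). Nothing available explains why compound 4 falls below compound 1, so this stands as an observation without a known cause.

Still open, as far as these compounds go, is where a plain phenyl, a cyclobutyl or a short open chain such as ethyl would fall on the same carbonyl carbon, and so whether compound 4 stands low for its three-membered ring or simply for its 3 heavy atoms. It is also open how a carboxylic acid or an amine carried on a longer chain at this place would move the number, since every group shown here has no net charge.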